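Butoxy to Benzyloxy at the Limit

This account rests on a few compounds, and the source may have more. Where it says the series, first, only, none or still open, it means among the compounds named here.

In an ADME assay on HepG2 cells (Homo sapiens) for cytotoxicity, read by luminescence, with a stated time of 72 h (a lower number here means that less compound is needed, a higher number that more compound is needed for the effect), compound 1 (`C=Cc1cccc(-c2[nH]c3cc(OC)ccc3c(=O)c2C(=O)OCC)c1`) gives > 21500 nM as a limit, not a number. Compound 2 (`CCCCOc1cccc(-c2[nH]c3cc(OC)ccc3c(=O)c2C(=O)OCC)c1`) gives > 21500 nM here, also a limit. Within the data shown here, the one measured step is a step that the two limits leave unreadable from compound 1 to compound 2 and it offers no size to carry forward. Compound 3 (`CCOC(=O)c1c(-c2cccc(OCc3ccccc3)c2)[nH]c2cc(OC)ccc2c1=O`) carries benzyloxy in place of butoxy (phenyl in place of propyl on a saturated chain carbon bound to an oxygen on an aromatic ring). Among the measured compounds shown here, compound 1 and compound 2 share the limit of > 21500 nM in this assay, at which 2 of the 2 values shown sit, and that is the only guide. The expected step that the limit leaves unreadable from compound 2 to compound 3 in this assay is no step beyond the scatter, in neither direction. For compound 3 the estimate is 30000 nM with an expected range of 15000 nM to 60000 nM and only a limit is expected.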

Compound 3, half-maximal effective concentration: > 21500 nM
Compound 3: no number, only a limit (the forecaster's own chance of this, stated with the estimate: 80%); the middle value is on the limit's open side.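

Compound 1, compound 2 and compound 3 all stop at the same assay limit, so no step between them can be read: the limit of > 21500 nM in this assay, at which 3 of the 3 values shown sit.

Still open, from the compounds shown here alone, is whether vinyl, butoxy or benzyloxy makes any difference in this assay.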